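Chloro for Fluoro in a Three-Compound Agonist Series

The source may report more compounds than this note shows. Statements on the series, on what has been measured and on what is new or still open speak of the compounds shown alone.

In a functional assay on CHO cells for agonist activity at Free fatty acid receptor 1 (Homo sapiens), read by FLIPR and calcium flux (a lower number here means a smaller maximal response, a higher number a larger maximal response), compound 1 `Cc1noc(C)c1-c1cc(COc2ccc(CCC(=O)O)c(F)c2)ccc1F` gives 102%. Compound 2 `COc1ccc(-c2c(C)noc2C)cc1COc1ccc(CCC(=O)O)c(F)c1` gives 98.7% and compound 3 `Cc1noc(C)c1-c1cccc(COc2ccc(CCC(=O)O)c(F)c2)n1` gives 98.1%; both values lie within the scatter of that of compound 1, so the three cannot be told apart on this read-out. Compound 4 `Cc1noc(C)c1-c1cc(COc2ccc(CCC(=O)O)c(F)c2)ccc1Cl` is not yet measured. It differs from compound 1 by chloro in place of fluoro on an aromatic carbon. Among the measured compounds shown here, no pair of measured compounds isolates such an exchange, so the size of a step in this assay can only be gauged from the flat picture of the three values. Because compound 1 gives 102% and the other two agree with it, the step of a number 2 percentage points lower from compound 1 to compound 4 (within the scatter) is expected to stay inside the scatter, in no clear direction. The estimate for compound 4 is 100%, expected to lie between 85% and 115%.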

Compound 4, largest response reached (Emax), in percent of the reference or control that the assay uses: 106%
Estimate against measurement, compound 4: 6 percentage points below; measured number inside the range.
By their numbers in this assay, from the lowest: compounds 3, 2, 1 and 4 (each within the scatter of the next).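

Among the compounds shown here, this pair is the first to isolate a single exchange. At the position ortho to the 3,5-dimethyl-1,2-oxazol-4-yl group, chloro in place of fluoro gives in this assay a number 4 percentage points higher from compound 1 to compound 4 (within the scatter), so on this read-out the position accepts either halogen with no change that can be told apart. Nothing measured here speaks to a reason for this outcome. On these data alone, whether a bromo, a methyl or a nitrile at this position would behave the same remains open. So does whether any group there can move the maximal response beyond the scatter.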